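From triazolyl to methylthiazolyl on the sulfur

The compounds below may be only part of what the source reports. "The series", "measured", "known", "first", "only" and "open" are said of these compounds alone.

Measured in a functional assay on SMMC-7721 cells (Homo sapiens) for antiproliferative activity, read by MTT assay, with a stated time of 72 h; a lower number here means a stronger inhibitor, a higher number a weaker inhibitor:
- compound 1 `C#CCSc1nc(Sc2ccccn2)c(C#N)c(-c2cc(OC)c(OC)c(OC)c2)n1`: > 20000 nM
- compound 2 `C#CCSc1nc(Sc2nc[nH]n2)c(C#N)c(-c2cc(OC)c(OC)c(OC)c2)n1`: > 20000 nM

Both entries are limits of the assay, not numbers. Compound 2 has only a limit, > 20000 nM. Going by the values given here, the one other value shown, for compound 1, is likewise a limit. The measured evidence therefore amounts to the limit of > 20000 nM in this assay, at which 2 of the 2 values shown sit.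

Compound 3 `C#CCSc1nc(Sc2nc(C)cs2)c(C#N)c(-c2cc(OC)c(OC)c(OC)c2)n1` carries 4-methyl-1,3-thiazol-2-yl in place of 1H-1,2,4-triazol-3-yl on a sulfur. Among the compounds with values here, the only measured step bearing on this change is at the same place, a step that the two limits leave unreadable from compound 1 to compound 2. It supplies no size to carry over and no direction, so compound 3 is expected to remain close to the limit in this assay. The expected step, a number no higher from compound 2 to compound 3 (the limit leaves the size open), is an estimate with no direction supported by the data. For compound 3 the estimated value is 20000 nM, with an expected range of 7000 nM to 50000 nM. A report of only a limit is the likelier outcome.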

Compound 3, half-maximal inhibitory concentration: > 20000 nM
Compound 3 ended at the assay's limit (the forecaster's own chance of this, stated with the estimate: 70%); the middle value sits exactly at the limit.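

Going by these compounds alone, compound 3 gives > 20000 nM, a limit of the assay and not a number, so no step from compound 1 or compound 2 to compound 3 can be read. The compounds shown leave open how the pyridin-2-yl, 1H-1,2,4-triazol-3-yl and 4-methyl-1,3-thiazol-2-yl groups on the sulfur rank in this assay, and whether any of them gives a measurable value there.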